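Phenyl for Cyclohexyl on the Amide Nitrogen of Compound 1

A few compounds are considered here, and "the series" means these few. Any claim that something is new, unique, unknown or untested is made for them only; others in the source may bear on it.

Measured compounds:
compound 1 `Cc1ccc(OCC(=O)N(Cc2cccs2)C2CCCCC2)cc1`, 40000 nM
compound 2 `Cc1ccc(/C=C/C(=O)N(Cc2cccs2)c2ccn[nH]2)cc1`, 0.004 nM
compound 3 `CCN(Cc1nccs1)C(=O)COc1ccc(C)cc1`, 3060 nM

In an assay on HEK293 cells for agonist activity at transient receptor potential cation channel subfamily M member 8 (Homo sapiens), read by fluorescence and calcium flux, with a stated time of 15 min (on this read-out lower numbers stand for an effect already at smaller amounts and higher numbers for an effect only at larger amounts of compound), compound 1 gives 40000 nM, the highest of the three numbers. Compound 3 is nearer to it, and compound 2 lies far away at the low end. None of these compounds differ from one another in a single place, so the three values show only how wide the range is, not what any one change does.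

Compound 4 `Cc1ccc(OCC(=O)N(Cc2cccs2)c2ccccc2)cc1` is not yet measured. It differs from compound 1 by phenyl in place of cyclohexyl on an amide-type nitrogen. Among the measured compounds shown here, no measured pair isolates this change. A modest move towards a lower number is expected, as a 2.7-fold lower number from compound 1 to compound 4 (0.43 log units; beyond the scatter), within the scatter or a little beyond it. Compound 4 is therefore expected to give about 15000 nM, between 3000 nM and 60000 nM.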

Compound 4, half-maximal effective concentration: 23 nM
Beside the measured number, compound 4's estimate is 650-fold (2.81 log units) above it, and the stated range ends above it.
By their numbers in this assay, from the lowest: compound 2; then compound 4; then compound 3; then compound 1.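

In this assay, phenyl in place of cyclohexyl on the amide-type nitrogen gives a 1700-fold lower number from compound 1 to compound 4 (3.24 log units; beyond the scatter), so this position responds strongly to the choice of ring. Both rings have six carbons and neither adds a hydrogen-bond donor or acceptor by the count, so the step comes with a change from a non-aromatic ring to an aromatic one. Nothing available explains why the step is this large. On these data alone, it remains open whether a pyridine ring or a benzyl group on this nitrogen would keep the low number. Whether the same swap has a similar effect on other cores is also unknown.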